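Changing One Group on a Shared Core

The source may hold more compounds than are shown below. What is called first, only, known or untested is meant among the compounds shown, and "the series" means these compounds.

Compound 1 `CC/C=C\C[C@H]1C(=O)C=C[C@H]1CC(=O)OCC`: 20000 nM
Compound 2 `CC/C=C\C[C@H]1C(=O)C=C[C@H]1CC(=O)OCc1ccccc1`: 20000 nM
Compound 3 `CC/C=C\C[C@H]1C(=O)C=C[C@H]1CC(=O)OCCOC`: 27000 nM

In a functional assay on RAW264.7 cells (Mus musculus) for inhibition, read by ELISA, with a stated time of 24 h (a lower number here means that less compound is needed, a higher number that more compound is needed for the effect), compound 3 gives 27000 nM, within the scatter of both compound 1 and compound 2. Compound 4 `CC/C=C\C[C@H]1C(=O)C=C[C@H]1CC(=O)OC1CCCCC1` differs from it by one change: cyclohexyl in place of 2-methoxyethyl on an oxygen next to a carbonyl group, in words cyclohexyl in place of 2-methoxyethyl on an oxygen next to a carbonyl group. Three measured steps altered the group on that same oxygen: no change at the digits printed from compound 1 to compound 2 (within the scatter), a 1.4-fold higher number from compound 1 to compound 3 (0.13 log units; within the scatter) and a 1.4-fold higher number from compound 2 to compound 3 (0.13 log units; within the scatter). Among the compounds with values here, none left the scatter, although no measured compound carries cyclohexyl, so no step beyond the scatter is expected. The expected step is a 1.4-fold lower number from compound 3 to compound 4 (0.13 log units; within the scatter). The estimated value for compound 4 is 20000 nM, with an expected range from 9000 nM to 42000 nM.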

Compound 4, half-maximal effective concentration: 22000 nM
Beside the measured number, compound 4's estimate is 1.1-fold (0.04 log units) below it; measured number inside the range.
By their numbers in this assay, from the lowest: compounds 1, 2, 4 and 3 (each within the scatter of the next).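

In this assay, cyclohexyl, the first ring of carbon only without aromatic character on an oxygen next to a carbonyl group, leaves the number within the scatter of all three earlier groups: a 1.2-fold lower number from compound 3 to compound 4 (0.09 log units; within the scatter), a 1.1-fold higher number from compound 2 to compound 4 (0.04 log units; within the scatter) and a 1.1-fold higher number from compound 1 to compound 4 (0.04 log units; within the scatter). Ethyl, benzyl, 2-methoxyethyl and cyclohexyl thus give numbers that cannot be told apart at this position. No available evidence accounts for this. On these data alone, whether a chain ending in an amine or a carboxylic acid on this oxygen would leave the scatter remains open.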